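This account rests on a few compounds, and the source may have more. Where it says the series, first, only, none or still open, it means among the compounds named here.

Working notes on the series. In a functional assay on A2780 cells (Homo sapiens) for inhibition (a lower number here means a stronger inhibitor, a higher number a weaker inhibitor), compound 3 `CC(C(=O)Nc1cc(C2CC2)[nH]n1)c1ccc(N2CCNC2=O)cc1` gives 2250 nM, the lowest number of the three measured. Compound 1 `CC(C(=O)Nc1cc(C2CC2)[nH]n1)c1ccc(N2C(=O)CCC2C)cc1` gives 6400 nM, and compound 2 `C[C@@H](C(=O)Nc1cc(C2CC2)[nH]n1)c1ccc(N2CCNC2=O)cc1` gives 13200 nM. The next structure, compound 4 `CC(C(=O)Nc1cc(C2CC2)[nH]n1)c1ccc(-n2ccnc2O)cc1`, differs from compound 3 in one place: a group of 6 heavy atoms (3 carbon, 2 nitrogen, 1 oxygen; one five-membered aromatic ring with 2 hetero atoms) in place of a group of 6 heavy atoms (3 carbon, 2 nitrogen, 1 oxygen; one five-membered non-aromatic ring with 2 hetero atoms), on an aromatic carbon. Like compound 3, it is drawn without a defined configuration.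

For the measured compounds named here, the closest precedent is the other exchange at this place, a 2.8-fold lower number from compound 1 to compound 3 (0.45 log units; beyond the scatter), a modest step. The second step, a 5.9-fold lower number from compound 2 to compound 3 (0.77 log units; beyond the scatter), is also modest, goes with the fact that one of compounds 2 and 3 is drawn with a defined configuration and the other without, at the place where they differ and leaves this group unchanged, so it gives no direct guide. Going by the values given here, no measured step replaces a non-aromatic ring with an aromatic one, so the direction is uncertain. Since compound 3 already holds the lowest number at 2250 nM, a modest move towards a higher number in this assay is expected. The estimated change is a 1.7-fold higher number from compound 3 to compound 4 (0.23 log units; within the scatter). The estimated value for compound 4 is 3800 nM, with an expected range of 1100 nM to 13000 nM.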

Compound 4, half-maximal inhibitory concentration: 6980 nM
Estimate against measurement, compound 4: 1.8-fold (0.26 log units) below; measured number inside the range.
By their numbers in this assay, from the lowest: compound 3; then compounds 1, 4 and 2 (each within the scatter of the next, the first and the last beyond it).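

In this assay, for the compounds shown here, putting the five-membered aromatic ring in place of 2-oxoimidazolidin-1-yl, on an aromatic carbon para to a large group, gives the only measured exchange of a non-aromatic ring for an aromatic one at this position (a 3.1-fold higher number from compound 3 to compound 4 (0.49 log units; beyond the scatter)). The same aromatic ring shows no separation from the group carried by compound 1 (a 1.1-fold higher number from compound 1 to compound 4 (0.04 log units; within the scatter)), so among these three groups on undefined-configuration compounds, only 2-oxoimidazolidin-1-yl stands apart, with compound 3 holding the lowest number. Nothing available on the series bears on why this exchange moves the number.

The compounds shown leave open whether an open-chain urea or a simple amine at this position would match compound 3. Going by these compounds alone, they also leave open how the single stereoisomers of compound 4 compare.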